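Amide substituent changes on the shared core

The compounds below may be only part of what the source reports. "The series", "measured", "known", "first", "only" and "open" are said of these compounds alone.

The series keeps one core and varies the amide. Compound 1 `CCn1c(C(=O)NCCCN(C)C)ccc1C(CC)(CC)c1ccc(OCCC(O)(CC)CC)c(C)c1` carries a 2-(dimethylamino)ethyl on the saturated chain carbon bound to the amide-type nitrogen; compound 2 `CCn1c(C(=O)NCC#N)ccc1C(CC)(CC)c1ccc(OCCC(O)(CC)CC)c(C)c1` carries a cyano at that place; compound 3 `CCn1c(C(=O)N(CCC#N)CCC#N)ccc1C(CC)(CC)c1ccc(OCCC(O)(CC)CC)c(C)c1` carries a group of 9 heavy atoms (6 carbon, 3 nitrogen; no ring) on the carbonyl carbon.

In a functional assay on HepG2 cells (Homo sapiens) for antiproliferative activity, read by MTT assay, with a stated time of 48 h (a higher number here means a weaker inhibitor, a lower number a stronger inhibitor), compound 1 gives 110 nM and compound 3 gives 46300 nM. Compound 2 gives only a limit of this assay, > 50000 nM (the limit of > 50000 nM in this assay, at which 1 of the 3 values shown sits), so it stands at the weak end of the three. The measured steps are an at least 450-fold higher number from compound 1 to compound 2 (2.65 log units; beyond the scatter) and a 420-fold higher number from compound 1 to compound 3 (2.62 log units; beyond the scatter), while an at least 1.0-fold lower number from compound 2 to compound 3 (0.03 log units; that floor lies within the scatter).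

Compound 4 `CCOC(=O)C(CC(=O)OC)NC(=O)c1ccc(C(CC)(CC)c2ccc(OCCC(O)(CC)CC)c(C)c2)n1CC` differs from compound 2 as follows: a group of 11 heavy atoms (7 carbon, 4 oxygen; no ring) in place of a group of 3 heavy atoms (2 carbon, 1 nitrogen; no ring), on an amide-type nitrogen. Both steps away from compound 1 were large, and the step from compound 2 to compound 3 stayed at the floor. Compound 4 keeps no group like that of compound 1, so no step beyond the scatter is expected, a step that the limit leaves unreadable from compound 2 to compound 4. For compound 4 in this assay the estimate is 60000 nM, with a range from 15000 nM to 200000 nM, and a limit rather than a number is likely.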

Compound 4, half-maximal inhibitory concentration: > 50000 nM
Compound 4 was reported as a limit; the forecaster's own chance of this, stated with the estimate: 60%; the middle value is on the limit's open side.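

Compound 4 adds a nitrile-free substituent at the amide-type nitrogen: the group of 11 heavy atoms (7 carbon, 4 oxygen) replaces cyanomethyl, and in this assay compound 4 is reported only as a limit, shared with compound 2: the limit of > 50000 nM in this assay, at which 2 of the 4 values shown sit.

The step between those two compounds cannot be read, so any effect of this exchange stays hidden, and the floor of an at least 1.0-fold higher number from compound 3 to compound 4 (0.03 log units; that floor lies within the scatter) gives no separation from compound 3 either. The gap to the amine-bearing compound remains large, with an at least 450-fold higher number from compound 1 to compound 4 (2.65 log units; beyond the scatter), so among these four compounds a nitrile is not required for the weak result: compounds 2, 3 and 4 all sit at the weak end, with no exception among them, and only compound 1 stands apart.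

From the compounds shown here alone, what remains open is whether the dimethylamino group of compound 1 or its chain accounts for the gap, and a primary amine, or a longer chain ending in a carboxylic acid, on the same amide-type nitrogen would begin to separate the two. The order among the weak compounds also stays undefined while two of them are limits.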